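The source may report more compounds than this note shows. Statements on the series, on what has been measured and on what is new or still open speak of the compounds shown alone.

In a functional assay on Caco-2 cells (Homo sapiens) for antiproliferative activity, with a stated time of 48 h (a lower number here means a stronger inhibitor, a higher number a weaker inhibitor), compound 1 `CCN(CC)c1ccc(-c2ccc(C(C)=O)cc2)nn1` gives 15000 nM and compound 2 `CCOC(=O)c1ccc(-c2ccc(N(CC)CC)nn2)cc1` gives 4000 nM, the lower of the two numbers. Compound 3 `CCCCOc1ccc(-c2ccc(C(=O)OCC)cc2)nn1` has butoxy in place of diethylamino on an aromatic carbon. Within the data shown here, the only measured step, a 3.8-fold lower number from compound 1 to compound 2 (0.57 log units; beyond the scatter), is modest and swaps ethoxy for methyl on a carbonyl carbon, so no measured step covers the aromatic-carbon change directly. No step beyond the scatter, in either direction, is therefore expected, and the estimate is a 1.3-fold higher number from compound 2 to compound 3 (0.10 log units; within the scatter). For compound 3 the estimated value is 5000 nM, with an expected range of 1500 nM to 18000 nM.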

Compound 3, half-maximal inhibitory concentration: > 25000 nM
Compound 3 ended at the assay's limit; the forecaster's own chance of this, stated with the estimate: 10%; middle value at least 5.0-fold (0.69 log units) from the limit.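

The aromatic carbon next to the ring nitrogen tolerates no free exchange: butoxy in place of diethylamino, with equal heavy-atom counts, gives an at least 6.2-fold higher number from compound 2 to compound 3 (0.79 log units; beyond the scatter). In this assay compound 3 gives > 25000 nM, which is a limit of the assay and not a number, so only the lower bound of this step is known. The reading rests on one such value: the limit of > 25000 nM in this assay, at which 1 of the 3 values shown sits.

The swap changes both the linking atom and the chain shape, and the compounds shown do not separate the two. As far as these compounds go, whether a pyrrolidine ring or a methoxy group on this carbon would sit with compound 2 or with compound 3 stays open.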